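Sulfonyl Aryl Swap on a Benzofuran Ketone Piperazine Series

The compounds below may be only part of what the source reports. "The series", "measured", "known", "first", "only" and "open" are said of these compounds alone.

Measured compounds in a functional assay on MCF7 cells (Homo sapiens) for cytotoxicity, read by MTT assay, with a stated time of 48 h; a lower number here means a stronger inhibitor, a higher number a weaker inhibitor:
compound 1, `CCN(CC)c1ccc2cc(C(=O)c3ccc(N4CCN(C(=O)COc5ccc(Cl)cc5Cl)CC4)cc3)oc2c1`, gives 12400 nM.
compound 2, `CCOC(=O)N1CCN(c2ccc(C(=O)c3cc4ccc(N(CC)CC)cc4o3)cc2)CC1`, reaches only the assay limit of > 40000 nM.
compound 3, `CCN(CC)c1ccc2cc(C(=O)c3ccc(N4CCN(S(=O)(=O)c5ccc(C(F)(F)F)cc5)CC4)cc3)oc2c1`, reaches only the assay limit of > 40000 nM.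

Compound 3 stands at the top of the numbers shown: in this assay compound 3 sits at a limit and not at a measured number, so its true value is unknown beyond that. Two of the three values shown share this position, as described by the limit of > 40000 nM in this assay, at which 2 of the 3 values shown sit. Only compound 1 gives a number.

Compound 4, `CCN(CC)c1ccc2cc(C(=O)c3ccc(N4CCN(S(=O)(=O)c5ccc(Br)c(F)c5)CC4)cc3)oc2c1`, is the next compound. It differs from compound 3 in one place: 4-bromo-3-fluorophenyl in place of 4-(trifluoromethyl)phenyl on a sulfonyl sulfur. Within the data shown here, the one measured step, an at least 3.2-fold higher number from compound 1 to compound 2 (0.50 log units; beyond the scatter), concerns a change on a carbonyl carbon at a different place from the sulfonyl sulfur, so it gives no direct guide to this change. The closest neighbour, compound 3, has no number but only a limit. Among the measured compounds shown here, no measured step therefore bears on the change in size or direction, and an expectation can rest only on the fact that compound 3 is already weaker than the measured range.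

For compound 4 in this assay the estimate is 40000 nM, within 15000 nM to 100000 nM, which means an expected step of a number no higher from compound 3 to compound 4 (the limit leaves the size open) and most likely another limit.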

Compound 4, half-maximal inhibitory concentration: 2270 nM
Compound 4: middle estimate off by 18-fold (1.25 log units), on the high side; measured number below the stated range.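

In this assay, the sulfonyl sulfur proves to be a sensitive position, since exchanging 4-(trifluoromethyl)phenyl for 4-bromo-3-fluorophenyl gives an at least 17-fold lower number from compound 3 to compound 4 (1.24 log units; beyond the scatter), so the sulfonyl link alone does not settle the outcome and the aryl group on it matters. On the amine nitrogen in the ring, (4-bromo-3-fluorophenyl)sulfonyl also gives lower numbers than both earlier groups, with an at least 17-fold lower number from compound 2 to compound 4 (1.24 log units; beyond the scatter) against ethoxycarbonyl and a 5.5-fold lower number from compound 1 to compound 4 (0.74 log units; beyond the scatter) against ((2,4-dichlorophenoxy)methyl)carbonyl. The two steps that start from compound 2 and compound 3 have no fixed upper size, as each begins at a limit and not at a measured number: the limit of > 40000 nM in this assay, at which 2 of the 4 values shown sit.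

The compounds shown leave open whether the bromine or the fluorine on the entering ring would hold the lower number on its own, or whether the two are needed together. They also leave open how this assay would respond to other groups on the sulfonyl sulfur, such as a plain phenyl, a pyridine ring or a methyl.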